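The source may hold more compounds than are shown below. What is called first, only, known or untested is meant among the compounds shown, and "the series" means these compounds.

Notes on the series. Among the compounds with values here, in an assay on isolated protein for binding affinity to Type-2 angiotensin II receptor (Homo sapiens) (on this read-out lower numbers stand for stronger inhibition and higher numbers for weaker inhibition), compound 1 `CCCc1nc(CC)c(C(=O)OCc2ccccc2S(=O)(=O)c2ccccc2)n1Cc1ccc(-c2ccccc2S(=O)(=O)NC(=O)OCCC(C)C)cc1F` gives 5 nM, the lowest of the two numbers measured so far. Compound 2 `CCCCN(Cc1ccccc1)C(=O)CCCOC(=O)c1c(CC)nc(CCC)n1Cc1ccc(-c2ccccc2-c2nn[nH]n2)cc1` gives 300 nM in this assay, a gap from compound 1 that lies well beyond the scatter; the two differ in several places at once, so only the two numbers themselves can be set side by side. Compound 3 `CCCc1nc(CC)c(C(=O)OCc2ccccc2-c2ccccc2)n1Cc1ccc(-c2ccccc2S(=O)(=O)NC(=O)OCCC(C)C)cc1F` has not been measured. It differs from compound 1 in phenyl in place of phenylsulfonyl on an aromatic carbon. Within the data shown here, no measured step of this kind is on hand, so the expected step of a 2.0-fold higher number from compound 1 to compound 3 (0.30 log units; within the scatter) is a small loss or nothing beyond the scatter. For compound 3 the estimate in this assay is 10 nM, with a range from 2 nM to 50 nM.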

Compound 3, half-maximal inhibitory concentration: 9 nM
Estimate against measurement, compound 3: 1.1-fold (0.05 log units) above; measured number inside the range.
By their numbers in this assay, from the lowest: compounds 1 and 3 (each within the scatter of the next); then compound 2.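

In this assay, within the data shown here, the first single-place step is a 1.8-fold higher number from compound 1 to compound 3 (0.26 log units; within the scatter), so phenyl in place of phenylsulfonyl on this aromatic carbon, ortho to a large group, gives no change beyond the scatter. The 2 hydrogen-bond acceptors that leave with phenylsulfonyl are therefore not required for a low number here. No measurement on hand gives a reason for this.

As far as these compounds go, whether an aromatic ring is needed at this place stays open. A carboxylic acid, an amine or a plain methyl on this aromatic carbon would address that.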